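A few compounds are considered here, and "the series" means these few. Any claim that something is new, unique, unknown or untested is made for them only; others in the source may bear on it.

Compound 2 `CC(C)n1c(=O)n(C(=O)NCCCN2CCN(C)CC2)c2ccccc21` and compound 3 `CN1CCN(CCCNC(=O)n2c(=O)n(C3CC3)c3ccccc32)CC1` share one core and part in a single place: cyclopropyl in place of isopropyl on an aromatic nitrogen. Going by the values given here, compound 1 `CCCN1CCN(CCNC(=O)n2c(=O)n(C3CC3)c3ccccc32)CC1` belongs to the same series and is the only member with a full number in a functional assay for agonist activity at 5-hydroxytryptamine receptor 4 (Cavia porcellus) (on this read-out higher numbers stand for larger maximal responses and lower numbers for smaller maximal responses), where compound 1 gives 0.41. For compound 2 this assay returns only a limit, < 0.3, and no number beyond that. Compound 2 thus sits at the limit of < 0.3 in this assay, at which 1 of the 2 values shown sits, and compound 3 has not yet been measured at all. Nothing measured joins compound 2 to compound 3 directly, so the size of the step can only be anticipated. Since compound 2 starts at the limit of < 0.3 in this assay, at which 1 of the 2 values shown sits, a step downward cannot be read; a step either within the scatter or modestly upward seems plausible, the upward case drawing on compound 1, which also bears cyclopropyl on the aromatic nitrogen and gives 0.41. Compound 3 is accordingly expected to reach about 0.35, within a range from 0.2 to 0.5. That estimate corresponds to an expected step of a number at least 0.050 higher from compound 2 to compound 3 (that floor lies within the scatter), upward but uncertain.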

Compound 3, intrinsic activity: the largest response reached, as a fraction of the reference agonist's: 0.46
The estimate for compound 3 lay 0.11 below the measured number, and the stated range covers the measured number.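

In this assay, going by these compounds alone, cyclopropyl in place of isopropyl on an aromatic nitrogen, with the rest of the molecule unchanged, gives a number at least 0.16 higher from compound 2 to compound 3 (beyond the scatter), the first direct reading of this change at this position. Compound 2 carries only a limit, so that step is a floor and its full size cannot be read: the limit of < 0.3 in this assay, at which 1 of the 3 values shown sits. The second change, (4-methylpiperazin-1-yl)methyl in place of 4-propylpiperazin-1-yl on a saturated chain carbon, gives a number 0.050 higher from compound 1 to compound 3 (within the scatter), so with cyclopropyl on the aromatic nitrogen in both compounds, this change in the side chain does not separate them on maximal response.

From the compounds shown here alone, only isopropyl and cyclopropyl appear on the aromatic nitrogen here, so it remains open whether a cyclobutyl or an ethyl group there would go with the larger maximal response of compound 3 or stay nearer the limit of compound 2. Going by these compounds, it is also open whether the step seen with the 4-methylpiperazin-1-yl side chain would hold with the 4-propylpiperazin-1-yl side chain of compound 1, or with a piperidine in place of the piperazine.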